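Working notes on the amide acid series, compounds 1 to 3

A few compounds are considered here, and "the series" means these few. Any claim that something is new, unique, unknown or untested is made for them only; others in the source may bear on it.

Measured so far:
compound 1 `O=C(N[C@H]1CC[C@H](C(=O)O)CC1)[C@H](C1CCCCC1)n1c(-c2ccc(Cl)nc2)nc2cc(F)c(F)cc21`: 18%
compound 2 `O=C(O)c1cccc(NC(=O)C(C2CCCCC2)n2c(-c3ccc(Cl)cc3)nc3cc(F)c(F)cc32)c1`: 14%

In a functional assay for agonist activity at Bile acid receptor (Homo sapiens), read by a luciferase reporter (a lower number here means a smaller maximal response, a higher number a larger maximal response), compound 1 gives 18%. In this assay compound 2 gives 14%. Compound 2 holds the lowest of the two numbers, but its gap to compound 1 lies within the scatter, so the two compounds cannot be told apart on these data; both sit at a low maximal response.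

Compound 3 `O=C(O)Cc1ccc(NC(=O)C(C2CCCCC2)n2c(-c3ccc(Cl)cc3)nc3cc(F)c(F)cc32)cc1` differs from compound 2 in one place: 4-(carboxymethyl)phenyl in place of 3-carboxyphenyl on an amide-type nitrogen. Among the measured compounds shown here, no pair of measured compounds shows a step of this kind, so nothing in the data sets its size or direction. Since the two measured compounds already agree within the scatter, the step of a number 3 percentage points higher from compound 2 to compound 3 (within the scatter) is expected to stay within the scatter as well, with no direction favoured. Compound 3 is expected to give 17%, estimated within the range 8% to 30%.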

Compound 3, largest response reached (reported as efficacy), in percent of the reference or control that the assay uses: 14%
For compound 3 the middle estimate is 3 percentage points above the measured one; measured number inside the range.
By their numbers in this assay, from the lowest: compounds 2, 3 and 1 (each within the scatter of the next).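

In this assay, among the compounds shown here, 4-(carboxymethyl)phenyl in place of 3-carboxyphenyl on the amide-type nitrogen gives no change at the digits printed from compound 2 to compound 3 (within the scatter) and provides the first step that can be read at this position. Up to now no single change had been tested here; this one shows that the maximal response stays low with either of these two carboxylic acid groups on that nitrogen. No measurement at hand explains the absence of a change across this step.

Whether any group at this position can raise the maximal response remains open, as both groups shown carry a carboxylic acid on a phenyl ring. A phenyl ring bearing an amine, or a longer chain ending in the carboxylic acid, would show whether the low response persists once that feature is altered.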